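Side-chain change on the compound 2 scaffold: working notes

This account rests on a few compounds, and the source may have more. Where it says the series, first, only, none or still open, it means among the compounds named here.

Among the compounds with values here, in a functional assay on A549 cells (Homo sapiens) for inhibition, read by MTT assay, with a stated time of 48 h (a lower number here means a stronger inhibitor, a higher number a weaker inhibitor), only two compounds have numbers so far. Compound 1 `C[Se]c1ccc(N(C)c2nc(C3CC3)nc3ccccc23)cc1` gives 13 nM. Compound 2 `COc1ccc(N(C)c2nc(C)nc3ccccc23)cc1OCCCCCC[Se]C#N` gives 5520 nM, the higher of the two numbers, and the gap between them lies beyond the scatter. Within the data shown here, the two compounds differ in more than one place, so no single-change step is available for calibration.

Compound 3 `COc1ccc(N(C)c2nc(C)nc3ccccc23)cc1C(=O)NCC[Se]C#N` keeps the shared core of compound 2 and changes one substituent: a group of 8 heavy atoms (4 carbon, 2 nitrogen, 1 oxygen, 1 selenium; no ring) in place of a group of 10 heavy atoms (7 carbon, 1 nitrogen, 1 oxygen, 1 selenium; no ring), on an aromatic carbon. The new group stands on an aromatic carbon, ortho to a methoxy group. Among the measured compounds shown here, with no measured precedent, only a small move towards a lower number is expected, and the direction is uncertain. The expected change is a 1.6-fold lower number from compound 2 to compound 3 (0.20 log units; within the scatter), an estimate that may not exceed the scatter. For compound 3 the estimated value in this assay is 3500 nM, with an expected range from 900 nM to 12000 nM.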

Compound 3, half-maximal inhibitory concentration: 187 nM
Compound 3: the middle estimate sits 19-fold (1.27 log units) above what was measured; measured number below the stated range.
By their numbers in this assay, from the lowest: compound 1; then compound 3; then compound 2.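

Within the data shown here, compound 3 gives the first single-change step: in this assay, the change at this position gives a 30-fold lower number from compound 2 to compound 3 (1.47 log units; beyond the scatter), so the number here moves strongly with the side chain on the aromatic carbon. The entering group differs from the leaving group in more than one respect, being smaller by count of heavy atoms and carrying a carbonyl double bond and a hydrogen-bond donor, and this single step cannot separate those differences. No measurement available here accounts for the size of the step.

Still open, as far as these compounds go, is whether the amide link or the shorter chain carries the change, which an amide with a longer chain would help to separate. Also open, from the compounds shown here alone, is what the selenium-bearing nitrile end contributes, and what a carboxylic acid or an amine at that chain end would give.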